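Nitro in place of hydrogen on the phenyl of compound 2

A few compounds are considered here, and "the series" means these few. Any claim that something is new, unique, unknown or untested is made for them only; others in the source may bear on it.

The series is read in a functional assay on the whole organism (plasma, strain Wistar) with Rattus norvegicus as the target, with a stated time of 15 days, at a dose of 30 mg/kg by the oral route; on this read-out higher numbers stand for a stronger effect at the one dose given and lower numbers for a weaker effect. Compound 1 `O=C1NC(=O)/C(=C/c2ccc(OCc3csc(-c4ccccc4)n3)cc2)S1` gives 22.6%, compound 3 `Cc1ccc(-c2nnc(SCCOc3ccc(/C=C4\SC(=O)NC4=O)cc3)[nH]2)cc1` gives 22.6%, and compound 2 `O=C1NC(=O)/C(=C/c2ccc(OCCSc3nnc(-c4ccccc4)[nH]3)cc2)S1` gives 14.7%, the smallest of the three numbers, though the gaps to compound 1 and to compound 3 both lie within the usual scatter. Among the measured compounds shown here, the only single-point step measured so far, methyl in place of hydrogen on an aromatic carbon, gave a number 7.9 percentage points higher from compound 2 to compound 3 (within the scatter), a change that does not rise above the scatter.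

Compound 4 `O=C1NC(=O)/C(=C/c2ccc(OCCSc3nnc(-c4ccc([N+](=O)[O-])cc4)[nH]3)cc2)S1` differs from compound 2 by nitro in place of hydrogen on an aromatic carbon. No measured pair in this set carries a nitro group, so nothing shown speaks directly to this change; the one step that touches the same phenyl, from a hydrogen to a methyl, stayed within the scatter. Compound 4 is therefore expected to land near compound 2, with a number 3.3 percentage points higher from compound 2 to compound 4 (within the scatter) as the estimated step. The estimate for compound 4 in this assay is 18%, within a range of 6% to 32%.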

Compound 4, a percentage reported as activity, at one dose (the size of the read-out at that dose, not a potency): 16%
Compound 4: the middle estimate sits 2 percentage points above what was measured, within the range that was stated.
By their numbers in this assay, from the lowest: compounds 2, 4, 1 and 3 (each within the scatter of the next).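

In this assay, phenyl to 4-nitrophenyl gave a number 1.3 percentage points higher from compound 2 to compound 4 (within the scatter), so a nitro group of 3 heavy atoms, para to a large group, leaves the number within the scatter of the unsubstituted compound. Nitro in place of methyl at that place gave a number 6.6 percentage points lower from compound 3 to compound 4 (within the scatter), and with a number 7.9 percentage points higher from compound 2 to compound 3 (within the scatter) as the third side of the comparison, hydrogen, methyl and nitro cannot be told apart on these numbers. Nothing shown here offers an explanation for this result.

From the compounds shown here alone, whether an amine, a carboxylic acid or a longer chain at this place would produce a step beyond the scatter remains open. Also open, going by these compounds, is whether these three compounds would stay within the scatter of one another at another dose.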